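The source may report more compounds than this note shows. Statements on the series, on what has been measured and on what is new or still open speak of the compounds shown alone.

Measured in a functional assay on MOLT-4 cells (Homo sapiens) for inhibition; a lower number here means a stronger inhibitor, a higher number a weaker inhibitor:
- compound 1 `O=C1/C(=C/c2cccc(Cl)c2)Cc2ccccc21`: 50900 nM
- compound 2 `O=C1/C(=C/c2cccc(Br)c2)Cc2ccccc21`: 173000 nM
- compound 3 `Cc1cccc(/C=C2\Cc3ccccc3C2=O)c1`: 80300 nM

Compound 3 stands together with compound 1 at the lower end of these three numbers. The series shows a 1.6-fold higher number from compound 1 to compound 3 (0.20 log units; within the scatter), and also a 2.2-fold lower number from compound 2 to compound 3 (0.33 log units; beyond the scatter).

Compound 4 `COc1cccc(/C=C2\Cc3ccccc3C2=O)c1` has methoxy in place of methyl on an aromatic carbon, meta to a large group (methoxy in place of methyl on an aromatic carbon). Within the data shown here, no measured step involves methoxy, so the evidence is indirect. It comes from the three exchanges among chloro, bromo and methyl on that carbon. Besides the two steps above, these include a 3.4-fold higher number from compound 1 to compound 2 (0.53 log units; beyond the scatter). All three are small, one lies within the scatter and none points to a direction for methoxy. In this assay, therefore, no step beyond the scatter is expected, and no direction is favoured. The expected change is a 1.1-fold higher number from compound 3 to compound 4 (0.02 log units; within the scatter). For compound 4 the estimated value is 85000 nM, with an expected range of 35000 nM to 200000 nM.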

Compound 4, half-maximal inhibitory concentration: > 500000 nM
Compound 4 ended at the assay's limit; the forecaster's own chance of this, stated with the estimate: 10%; middle value at least 5.8-fold (0.76 log units) away from the limit.
By their numbers in this assay, from the lowest: compounds 1 and 3 (each within the scatter of the next); then compound 2. At a limit, above all of these: compound 4.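

In this assay compound 4 gives > 500000 nM, which is a limit of the assay and not a number. All three exchanges to methoxy at this position, on an aromatic carbon meta to a large group, lead to a weaker inhibitor: an at least 6.2-fold higher number from compound 3 to compound 4 (0.79 log units; beyond the scatter), an at least 2.8-fold higher number from compound 2 to compound 4 (0.46 log units; beyond the scatter) and an at least 9.8-fold higher number from compound 1 to compound 4 (0.99 log units; beyond the scatter). The earlier exchanges among chloro, bromo and methyl had shown only small steps, whereas methoxy shows that the group on this carbon can weaken inhibition further than any of those three.

From the compounds shown here alone, the true size of these steps stays open, since each is bounded only by the limit. The compounds shown also do not tell whether the loss goes with the oxygen or with the added heavy atom, a question on which a hydroxy or an ethyl on the same carbon would bear.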